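Estimating compound 4 from a trifluoromethyl step

This account rests on a few compounds, and the source may have more. Where it says the series, first, only, none or still open, it means among the compounds named here.

In a functional assay on MCF7 cells (Homo sapiens) for inhibition, read by MTT assay, with a stated time of 72 h (on this read-out higher numbers stand for weaker inhibition and lower numbers for stronger inhibition), compound 1 (`O=C(O)CCCCCCC(=O)Nc1ccc(C2=C(c3ccc(O)cc3)C3CC(S(=O)(=O)Oc4ccccc4C(F)(F)F)C2O3)cc1`) gives 26100 nM, compound 2 (`COC(=O)CCCCCCC(=O)Nc1cccc(OS(=O)(=O)C2CC3OC2C(c2ccc(O)cc2)=C3c2ccc(O)cc2)c1`) gives 19100 nM and compound 3 (`Cc1ccccc1OS(=O)(=O)C1CC2OC1C(c1ccc(NC(=O)CCCCCCC(=O)O)cc1)=C2c1ccc(O)cc1`) gives 7900 nM, the lowest of the three numbers. Compound 4 (`O=C(O)CCCCCCC(=O)Nc1ccc(C2=C(c3ccc(O)cc3)C3CC(S(=O)(=O)Oc4ccc(C(F)(F)F)cc4)C2O3)cc1`) has 4-(trifluoromethyl)phenyl in place of the 2-methylphenyl of compound 3, on an oxygen whose other neighbour is the sulfonyl sulfur (4-(trifluoromethyl)phenyl in place of 2-methylphenyl on an oxygen). For the measured compounds named here, one measured step bears on this change: a 3.3-fold lower number from compound 1 to compound 3 (0.52 log units; beyond the scatter), with methyl in place of trifluoromethyl on an aromatic carbon. Compound 1 does not carry the 4-(trifluoromethyl)phenyl group, so that step is only a partial guide. The expected change is a 1.8-fold higher number from compound 3 to compound 4 (0.25 log units; within the scatter), toward weaker inhibition. For compound 4 the estimate is 14000 nM, with an expected range of 6500 nM to 30000 nM.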

Compound 4, half-maximal inhibitory concentration: 24000 nM
Compound 4: the middle estimate sits 1.7-fold (0.23 log units) below what was measured; measured number inside the range.
By their numbers in this assay, from the lowest: compound 3; then compounds 2, 4 and 1 (each within the scatter of the next).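

In this assay, the step of a 1.1-fold lower number from compound 1 to compound 4 (0.04 log units; within the scatter) shows that exchanging 2-(trifluoromethyl)phenyl for 4-(trifluoromethyl)phenyl on this oxygen does not separate the two compounds. The step of a 3.0-fold higher number from compound 3 to compound 4 (0.48 log units; beyond the scatter) places compound 4 with compound 1 on the weaker side of compound 3, so among these three compounds only the 2-methylphenyl group stands apart. No measurement given here accounts for this difference.

From the compounds shown here alone, it remains open whether a methyl group placed elsewhere on this ring would keep the value of compound 3. Going by these compounds, whether a methoxy group, a chlorine or an amine on this ring would do the same also remains open.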